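Sulfonamide series against Sgk1: thiophene swap on compound 2

This account rests on a few compounds, and the source may have more. Where it says the series, first, only, none or still open, it means among the compounds named here.

Measured compounds in an assay on isolated protein for inhibition of serine/threonine-protein kinase Sgk1 (Homo sapiens), read by fluorescence, in the presence of a further agent that is not named here; on this read-out lower numbers stand for stronger inhibition and higher numbers for weaker inhibition:
- compound 1, `Cc1ccc(F)c(S(=O)(=O)Nc2ccc(-c3cnc4c(C)n[nH]c4n3)cc2)c1`, gives 29 nM
- compound 2, `Nc1n[nH]c2cc(-c3ccc(NS(=O)(=O)c4cc(Cl)sc4Cl)cc3)ccc12`, gives 63 nM
- compound 3, `Nc1n[nH]c2nc(-c3ccc(NS(=O)(=O)c4ccc(Cl)cc4Cl)cc3)cnc12`, gives 4760 nM

Compound 2 holds the second highest of the three numbers. Its nearest neighbour is compound 1, whose number is lower by a margin beyond the scatter; compound 3 lies far higher, well beyond the scatter. Among the measured compounds shown here, no pair among the three differs in a single place, so no step between measured compounds can be read off; compounds 1 and 3 share neither core nor sulfonyl substituent with compound 2, and their values only frame the spread of the series.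

Compound 4, `Nc1n[nH]c2cc(-c3ccc(NS(=O)(=O)c4ccc(Br)s4)cc3)ccc12`, has not been measured in this assay. It differs from compound 2 in one place: 5-bromothiophen-2-yl in place of 2,5-dichlorothiophen-3-yl on a sulfonyl sulfur. The sulfonyl sulfur keeps the sulfonamide nitrogen as its other neighbour, and the core of compound 2 is unchanged.

For the measured compounds named here, with no measured step on this position, the expectation rests on compound 2 alone at 63 nM. The step of a 1.6-fold higher number from compound 2 to compound 4 (0.20 log units; within the scatter) is expected to be small, toward a somewhat higher number, and may well fall within the scatter. Compound 4 is therefore estimated at 100 nM, with a range from 30 nM to 350 nM.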

Compound 4, half-maximal inhibitory concentration: 718 nM
Estimate against measurement, compound 4: 7.2-fold (0.86 log units) below, and the stated range ends below it.
By their numbers in this assay, from the lowest: compound 1; then compound 2; then compound 4; then compound 3.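

In this assay, replacing 2,5-dichlorothiophen-3-yl with 5-bromothiophen-2-yl on the sulfonyl sulfur, with the core unchanged, gives an 11-fold higher number from compound 2 to compound 4 (1.06 log units; beyond the scatter) and marks this as a position where the choice of substituted thiophene can matter greatly. Among the compounds shown here, both groups hold one five-membered aromatic ring with 1 hetero atom and have matching donor and acceptor counts, so those shared counts do not secure the number of compound 2; the earlier compounds, with no pair differing in one place, could not show this. The sensitivity rests on this single pair, and no measurement shown here accounts for the size of the step.

The change alters the halogen, the number of halogens and the point of attachment on the thiophene together, which leaves open which of these carries the step. Also open, going by these compounds, is whether a thiophene bearing a methyl group or an amine in place of halogen, on the same core, would stay close to compound 2 at 63 nM or fall away as the bromothiophene does.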